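From 4-methylbenzyl to allyl: what compound 4 may show

The source may hold more compounds than are shown below. What is called first, only, known or untested is meant among the compounds shown, and "the series" means these compounds.

In a functional assay on MDA-MB-231 cells (Homo sapiens) for inhibition, read by sulforhodamine B assay, with a stated time of 48 h (a lower number here means a stronger inhibitor, a higher number a weaker inhibitor), compound 1 `COc1ccc(/C(=N/O)c2cccc3ccccc23)c(OC)c1OC` gives 2500 nM as its half-maximal inhibitory concentration, and compound 3 `CCOC(=O)CO/N=C(/c1ccc(OC)c(OC)c1OC)c1cccc2ccccc12` gives 16400 nM in the same test.

Compound 2 `COc1ccc(C(O)(Cc2ccc(C)cc2)c2cccc3ccccc23)c(OC)c1OC` has no number, only a limit of the assay (> 20000 nM). The series thus holds the limit of > 20000 nM in this assay, at which 1 of the 3 values shown sits, and compound 2 is the one that sits there.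

Compound 4 `C=CCC(O)(c1ccc(OC)c(OC)c1OC)c1cccc2ccccc12` differs from compound 2 as follows: vinyl in place of 4-methylphenyl on a saturated chain carbon, two bonds along the chain from two aromatic carbons and an oxygen on a saturated carbon.

Within the data shown here, no measured step covers this change. The only one available, a 6.6-fold higher number from compound 1 to compound 3 (0.82 log units; beyond the scatter), came with (ethoxycarbonyl)methyl in place of hydrogen on an oxygen, so it serves merely as a gauge of size. Going by compound 3 at 16400 nM, a modest move toward a lower number is expected in this assay, although compound 4 may well remain weak.

The expected step is an at least 1.5-fold lower number from compound 2 to compound 4 (0.18 log units; that floor lies within the scatter) in this estimate. Compound 4 is expected at 13000 nM, with an estimated range from 4000 nM to 20000 nM in the same assay.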

Compound 4, half-maximal inhibitory concentration: > 20000 nM
Compound 4 gave a limit, no number; the forecaster's own chance of this, stated with the estimate: 40%; middle value at least 1.5-fold (0.18 log units) away from the limit.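

In this assay compound 4, like compound 2, gives only a limit and not a number, so no step can be read between these two compounds. The series now holds: the limit of > 20000 nM in this assay, at which 2 of the 4 values shown sit.

The compounds shown leave open how strong compound 2 and compound 4 actually are, and whether the change from 4-methylbenzyl to allyl moves the number at all.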